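The compounds below may be only part of what the source reports. "The series", "measured", "known", "first", "only" and "open" are said of these compounds alone.

Compound 1 `Cc1ccc(/C=C2\CN(C)CC3=C2N=C(S)NC3c2ccc(C)cc2)cc1` gives 53700 nM in a functional assay on cells (Panel CNS (Carcinoma cell lines), Homo sapiens) for inhibition; a higher number here means a weaker inhibitor of growth, a lower number a stronger inhibitor of growth. Compound 2 `CN1C/C(=C\c2cccs2)C2=NN(C)C(c3cccs3)C2C1` gives 80700 nM in this assay.

The two values for compound 1 and compound 2 sit within the usual scatter of each other, so neither stands apart from the other. Compound 3 `CN1C/C(=C\c2cccs2)C2=NN(c3ccccc3)C(c3cccs3)C2C1` differs from compound 2 by phenyl in place of methyl on an amine nitrogen in a ring. Within the data shown here, no comparable step among the measured compounds exists to guide this change, so no shift beyond the scatter in this assay is expected in either direction. Compound 3 is therefore expected to give about 60000 nM, within a range from 20000 nM to 150000 nM. That estimate means an expected step of a 1.3-fold lower number from compound 2 to compound 3 (0.13 log units; within the scatter), staying within the scatter.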

Compound 3, concentration for 50% growth inhibition: 35700 nM
For compound 3 the middle estimate is 1.7-fold (0.23 log units) above the measured one, and the stated range covers the measured number.
By their numbers in this assay, from the lowest: compounds 3, 1 and 2 (each within the scatter of the next, the first and the last beyond it).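

In this assay, among these compounds, phenyl in place of methyl on an amine nitrogen in a ring gives a 2.3-fold lower number from compound 2 to compound 3 (0.35 log units; beyond the scatter), the only step so far between compounds differing in one place. It shows that this position, next to the ring atom that bears a thiophen-2-yl group, accepts an aromatic ring with a modest gain in growth inhibition. Nothing available explains this gain. On these data alone, whether a benzyl group, a pyridine ring or a longer chain at this nitrogen would go further stays open. One step also cannot show whether size or aromatic character matters here.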